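A Second Hydroxy Group on the Pendant Ring

The source may report more compounds than this note shows. Statements on the series, on what has been measured and on what is new or still open speak of the compounds shown alone.

Among the measured compounds shown here, compound 3 `COc1cc(-n2c(-c3ccc(O)cc3)csc2=S)cc(OC)c1OC` is the only member of this small series to return a number in a functional assay on MCF7 cells (Homo sapiens) for cytotoxicity, read by MTT assay, with a stated time of 48 h (on this read-out lower numbers stand for stronger inhibition and higher numbers for weaker inhibition), where compound 3 gives 35.1 ug/mL. Compound 1 `COc1cc(-n2c(-c3ccccc3)csc2=S)cc(OC)c1OC` gives > 100 ug/mL in this assay, which is a limit of the assay rather than a number. Compound 2 `COc1cc(-n2c(-c3ccc(Br)cc3)csc2=S)cc(OC)c1OC` likewise gives > 100 ug/mL in this assay, again only a limit. Compound 4 `COc1cc(-n2c(-c3ccc(O)c(O)c3)csc2=S)cc(OC)c1OC` differs from compound 3 in one place: hydroxy in place of hydrogen on an aromatic carbon. For the measured compounds named here, two measured steps bear on this change. The step of an at least 2.8-fold lower number from compound 1 to compound 3 (0.45 log units; beyond the scatter) and the step of an at least 2.8-fold lower number from compound 2 to compound 3 (0.45 log units; beyond the scatter) both introduce a hydroxy group on the pendant ring, and each reads as a lowering of the number beyond the scatter. The step that the two limits leave unreadable from compound 1 to compound 2, in contrast, cannot be read, since both of its ends are limits. A second hydroxy group, placed ortho to a hydroxy group already present, is therefore expected to lower the number modestly or to leave it within the scatter of compound 3, with a lowering held more likely on the strength of an at least 2.8-fold lower number from compound 2 to compound 3 (0.45 log units; beyond the scatter). The estimate for compound 4 in this assay is 20 ug/mL, expected to fall between 7 ug/mL and 60 ug/mL. This corresponds to an expected step of a 1.8-fold lower number from compound 3 to compound 4 (0.24 log units; within the scatter).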

Compound 4, half-maximal inhibitory concentration: > 100 ug/mL
Compound 4: no number, only a limit; the forecaster's own chance of this, stated with the estimate: 10%; middle value at least 5.0-fold (0.69 log units) away from the limit.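

In this assay, the earlier steps had shown only a lower number on introducing a hydroxy group on the pendant ring, whereas going on to the 3,4-dihydroxyphenyl group gives an at least 2.8-fold higher number from compound 3 to compound 4 (0.45 log units; beyond the scatter). The same change, hydroxy in place of hydrogen on an aromatic carbon, therefore runs in opposite directions within this series: the number fell on reaching compound 3 from compound 1, and it rose when the new hydroxy group stood ortho to a hydroxy group. This rise is known only as a minimum, and the steps from compound 1 and from compound 2 to compound 4 cannot be read, since all three compounds sit at the same limit: the limit of > 100 ug/mL in this assay, at which 3 of the 4 values shown sit.

The compounds shown leave open whether the loss belongs to a hydroxy group in particular or would follow any group placed ortho to the hydroxy group of the 4-hydroxyphenyl ring. From the compounds shown here alone, a methoxy group, a fluoro group or an amine at that place would separate these readings, and how far compound 4 lies beyond its limit also stays unknown.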